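Methoxy for methyl on the shared core

The source may report more compounds than this note shows. Statements on the series, on what has been measured and on what is new or still open speak of the compounds shown alone.

In a functional assay on NCI-H460 cells (Homo sapiens) for cytotoxicity (a higher number here means a weaker inhibitor, a lower number a stronger inhibitor), compound 1 `CS(=O)(=O)c1ccc2nc(NC(=O)CCCCCCC(=O)NO)sc2c1` gives 6.54 ug/mL and compound 2 `Cc1ccc2nc(NC(=O)CCCCCCC(=O)NO)sc2c1` gives 0.84 ug/mL as the lower of the two numbers. Going by the values given here, the one measured step of a 7.8-fold lower number from compound 1 to compound 2 (0.89 log units; beyond the scatter) is methyl in place of methylsulfonyl on an aromatic carbon and lies beyond the scatter. Compound 3 `COc1ccc2nc(NC(=O)CCCCCCC(=O)NO)sc2c1` keeps the shared core and has methoxy in place of methyl on an aromatic carbon at that same carbon. Among the compounds with values here, no measured compound carries methoxy, so the step from compound 1 is only a loose guide: it shows that a change at this carbon can move this assay beyond the scatter. A much smaller step is expected here, towards a slightly higher number and within the scatter. The expected step is a 1.4-fold higher number from compound 2 to compound 3 (0.15 log units; within the scatter) on this reading. Compound 3 is estimated at 1.2 ug/mL with an expected range from 0.4 ug/mL to 3.5 ug/mL in this series.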

Compound 3, half-maximal inhibitory concentration: 1.25 ug/mL
Compound 3: middle estimate off by 1.0-fold (0.02 log units), on the low side; low and high end bracket the measured number.
By their numbers in this assay, from the lowest: compounds 2 and 3 (each within the scatter of the next); then compound 1.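

In this assay, methoxy at this aromatic carbon does not separate from methyl: a 1.5-fold higher number from compound 2 to compound 3 (0.17 log units; within the scatter), so the swap that adds one oxygen and one hydrogen-bond acceptor stays within the scatter. The gap to methylsulfonyl remains, with a 5.2-fold lower number from compound 1 to compound 3 (0.72 log units; beyond the scatter), and it now holds against two different groups rather than methyl alone. Among the three groups at this carbon, only methylsulfonyl stands apart, while methyl and methoxy cannot be told apart.

The compounds shown leave open whether an amine, chlorine or a carboxylic acid at this carbon would fall with methyl and methoxy or with methylsulfonyl. They also leave open whether the same grouping would hold with a shorter chain on the shared core. No measured evidence bears on these numbers.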